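The source may report more compounds than this note shows. Statements on the series, on what has been measured and on what is new or still open speak of the compounds shown alone.

Compound 2 `O=C1O[C@H]([C@@H](O)Cn2cc(CCO)nn2)C(OCc2ccccc2)=C1OCc1ccccc1` stands at the weak end of the two measured compounds. In a functional assay on SW-620 cells (Homo sapiens) for antiproliferative activity, read by MTT assay, with a stated time of 72 h (on this read-out lower numbers stand for stronger inhibition and higher numbers for weaker inhibition), compound 2 gives only a limit, > 100000 nM. Compound 1 `CCCCc1cn(C[C@H](O)[C@H]2OC(=O)C(OCc3ccccc3)=C2OCc2ccccc2)nn1`, which carries a butyl chain in place of the hydroxyethyl arm, gives in this assay a numbered result of 47500 nM. The step of an at least 2.1-fold higher number from compound 1 to compound 2 (0.32 log units; beyond the scatter) is thus only a bound because compound 2 sits at the limit of > 100000 nM in this assay, at which 1 of the 2 values shown sits. Compound 3 `O=C1O[C@H]([C@@H](O)Cn2cc(CNS(=O)(=O)c3ccc(Cl)cc3F)nn2)C(OCc2ccccc2)=C1OCc1ccccc1` brings a different change: ((4-chloro-2-fluorophenyl)sulfonyl)amino in place of hydroxymethyl on a saturated chain carbon bound to an aromatic carbon. Among the measured compounds shown here, the one measured step exchanged a small chain end for a hydroxy group and weakened activity, whereas here a hydroxymethyl gives way to a far larger aromatic sulfonamide, so that step is a poor guide. With compound 2 already at the limit, a further worsening could not be seen, and compound 3 is expected to show the step of an at least 3.3-fold lower number from compound 2 to compound 3 (0.52 log units; beyond the scatter), back toward the range of compound 1. The estimate for compound 3 is 30000 nM, ranging from 5000 nM to 100000 nM.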

Compound 3, half-maximal inhibitory concentration: 42400 nM
Compound 3: the middle estimate sits 1.4-fold (0.15 log units) below what was measured; low and high end bracket the measured number.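

In this assay, putting the far larger ((4-chloro-2-fluorophenyl)sulfonyl)amino in place of hydroxymethyl gives an at least 2.3-fold lower number from compound 2 to compound 3 (0.37 log units; beyond the scatter), so the loss seen with the hydroxyethyl arm is not the fate of every change at this chain end. That step is only a bound because compound 2 stands at a limit, not at a number: the limit of > 100000 nM in this assay, at which 1 of the 3 values shown sits. Replacing propyl with the same group gives a 1.1-fold lower number from compound 1 to compound 3 (0.05 log units; within the scatter), so the plain alkyl chain and the much bulkier aromatic sulfonamide cannot be told apart here, and neither stands out as the better end group.

The compounds shown cannot separate the part played by the sulfonyl amino link from that of the chloro- and fluoro-substituted ring. As far as these compounds go, how an amine, a carboxylic acid or a longer alkyl chain would read at this place also remains open.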